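Lengthening the side chain of compound 2

The source may hold more compounds than are shown below. What is called first, only, known or untested is meant among the compounds shown, and "the series" means these compounds.

Measured in a functional assay on L1210 cells (Mus musculus) for cytotoxicity; on this read-out lower numbers stand for an effect already at smaller amounts and higher numbers for an effect only at larger amounts of compound:
- compound 1 `COc1ccc(OC)c2c1C(=O)C=C(CO)C2=O`: 0.524 ug/mL
- compound 2 `CCCCCC(O)c1cc(OC)c2c(c1OC)C(=O)C=CC2=O`: 0.066 ug/mL
- compound 3 `CCCCCCCC(O)C1=CC(=O)c2c(OC)ccc(OC)c2C1=O`: 1.04 ug/mL

All three share a quinone core carrying two methoxy groups and a side chain that bears an oxygen on a saturated carbon. Among these three, compound 2 gives the lowest number in this assay; compound 1 sits well above it, and compound 3 further still, both beyond the usual scatter.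

Compound 4 `CCCCCCCC(O)c1cc(OC)c2c(c1OC)C(=O)C=CC2=O` is the unmeasured partner of compound 2. The change is ethyl in place of hydrogen on a saturated chain carbon, six bonds along the chain from an aromatic carbon and an oxygen on a saturated carbon. Among the compounds with values here, the one measured step that speaks to a longer chain is a 2.0-fold higher number from compound 1 to compound 3 (0.30 log units; within the scatter), where heptyl took the place of hydrogen on a saturated chain carbon bound to a double-bonded ring carbon and an oxygen on a saturated carbon. That step was small and within the scatter, although it sits on a core in which the side chain is attached differently from compound 2.

Within the data shown here, with only that step as a guide, a step of similar size is expected: a 1.5-fold higher number from compound 2 to compound 4 (0.18 log units; within the scatter). Compound 4 is therefore estimated at 0.1 ug/mL in this assay, with a range from 0.04 ug/mL to 0.25 ug/mL.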

Compound 4, concentration for half-maximal effect: 0.274 ug/mL
The estimate for compound 4 lay 2.7-fold (0.44 log units) below the measured number; measured number above the stated range.
By their numbers in this assay, from the lowest: compound 2; then compounds 4, 1 and 3 (each within the scatter of the next, the first and the last beyond it).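

On the core of compound 2, lengthening the chain has a real effect: in this assay ethyl in place of hydrogen on a saturated chain carbon gives a 4.2-fold higher number from compound 2 to compound 4 (0.62 log units; beyond the scatter) and so lies beyond the usual scatter, meaning that more of compound 4 is needed for the same effect. The earlier chain step on the differently attached side chain, a 2.0-fold higher number from compound 1 to compound 3 (0.30 log units; within the scatter) and within the scatter, therefore does not carry over to this core, so the response to a longer chain cannot be assumed to be the same on both. Nothing available explains why the number rises here.

Within the data shown here, it remains open whether a still longer chain would raise the number further on this core, or whether a shorter chain would lower it, since this single pair shows only one step in one direction. Also open, going by these compounds, is how this position would respond to something other than plain carbon at the end of the chain, such as an amine or a carboxylic acid.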